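Benzyl chlorine removal in the pyrrolidine carboxamide series

The compounds below may be only part of what the source reports. "The series", "measured", "known", "first", "only" and "open" are said of these compounds alone.

Measured so far:
compound 1 `CC(C)(C)N1C[C@@H](C(=O)Nc2nccn2Cc2cccc(Cl)c2)[C@H](c2ccc(F)cc2F)C1` gives 1270 nM
compound 2 `Cc1ccc(Cn2ccnc2NC(=O)[C@@H]2CN(C(C)(C)C)C[C@H]2c2ccc(F)cc2F)c(N2CCC(C(=O)O)CC2)c1` gives 318 nM

In a functional assay for agonist activity at Melanocyte-stimulating hormone receptor (Homo sapiens), read by cAMP accumulation (on this read-out lower numbers stand for an effect already at smaller amounts and higher numbers for an effect only at larger amounts of compound), compound 1 stands at the higher of the two numbers; compound 2 gives the lower one, and the two values lie beyond the usual scatter of each other. Going by the values given here, no single-point step between measured compounds is available, so the shared core is so far characterised only by these two points.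

Compound 3 `CC(C)(C)N1C[C@@H](C(=O)Nc2nccn2Cc2ccccc2)[C@H](c2ccc(F)cc2F)C1` is the analogue of compound 1 with hydrogen in place of chloro on an aromatic carbon of the benzyl group. Among the compounds with values here, with no measured step to lean on, the expectation for this assay is a small shift towards a higher number, at the edge of the scatter, since the change is the loss of a single heavy atom.

Compound 3 is therefore estimated at 2000 nM (range 800 nM to 5000 nM), an expected step of a 1.6-fold higher number from compound 1 to compound 3 (0.20 log units; within the scatter) in this assay.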

Compound 3, half-maximal effective concentration: 4660 nM
The estimate for compound 3 lay 2.3-fold (0.37 log units) below the measured number, and the stated range covers the measured number.
By their numbers in this assay, from the lowest: compound 2; then compound 1; then compound 3.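

In this assay, going by these compounds alone, the change from 3-chlorobenzyl to benzyl gives a 3.7-fold higher number from compound 1 to compound 3 (0.56 log units; beyond the scatter), the first single-point step. This aromatic carbon of the benzyl group is therefore not indifferent to substitution: exchanging one chlorine for hydrogen, with no ring, hydrogen-bond donor, hydrogen-bond acceptor or net charge entering or leaving, is enough to move the read-out beyond the usual scatter. The data at hand offer no independent measurement that would account for this step.

From the compounds shown here alone, it remains open whether the step is specific to chloro, or whether fluoro, methyl, methoxy or trifluoromethyl on the same carbon would give a similar number. Compound 2 differs from compound 1 in more than one place, so it does not help settle this question.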